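Hydrogen in place of carboxy on compound 1

The source may report more compounds than this note shows. Statements on the series, on what has been measured and on what is new or still open speak of the compounds shown alone.

Measured so far:
Compound 1 (`COc1ccc(-c2cc(C(=O)O)sc2-c2cc(OC)c(OC)c(OC)c2)cc1OCc1ccccc1`) gives > 100000 nM as a limit of the assay
Compound 2 (`COc1ccc(-c2cc(C(=O)O)sc2-c2cc(OC)c(OC)c(OC)c2)cc1O`) gives 17500 nM as its value

Compound 1 has no number in a functional assay on SGC-7901 cells (Homo sapiens) for antiproliferative activity, read by MTT assay, with a stated time of 72 h (a lower number here means a stronger inhibitor, a higher number a weaker inhibitor), only a limit, and so stands at the limit of > 100000 nM in this assay, at which 1 of the 2 values shown sits, in this small set. Compound 3 (`COc1ccc(-c2ccsc2-c2cc(OC)c(OC)c(OC)c2)cc1OCc1ccccc1`) keeps the benzyl group of compound 1 but carries hydrogen in place of carboxy on an aromatic carbon, next to the ring sulfur (hydrogen in place of carboxy on an aromatic carbon).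

Among the compounds with values here, the one measured step (an at least 5.7-fold lower number from compound 1 to compound 2 (0.75 log units; beyond the scatter)) lies beyond the scatter, but it puts hydrogen in place of benzyl on an oxygen on an aromatic ring, which is a different place. Within the data shown here, no measured step therefore tests the carboxy group directly, and the expected size in this assay is poorly fixed. Starting from a limit, any number found can only lie lower, so a step of at least modest size toward a lower number is expected, though compound 3 may also stay at the limit. The expected move is an at least 6.6-fold lower number from compound 1 to compound 3 (0.82 log units; beyond the scatter) in this estimate. For compound 3 the expected value is 15000 nM, with an estimated range from 1000 nM to 100000 nM.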

Compound 3, half-maximal inhibitory concentration: > 100000 nM
Compound 3: a limit, no number; the forecaster's own chance of this, stated with the estimate: 30%; at least 6.6-fold (0.82 log units) between middle value and limit.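

In this assay, compound 3, like compound 1, gives only a limit and no number, so the step between compound 1 and compound 3 cannot be read: the limit of > 100000 nM in this assay, at which 2 of the 3 values shown sit.

The compounds shown leave open whether hydrogen in place of carboxy on an aromatic carbon changes the antiproliferative activity at all, and in which direction.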